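Exchanging the Aryl Group on the Exocyclic Double Bond

This account rests on a few compounds, and the source may have more. Where it says the series, first, only, none or still open, it means among the compounds named here.

Measured compounds:
compound 1, `CC1=C(C(=O)Nc2ccc(F)cc2)C(c2ccc(Br)cc2)n2c(s/c(=C/c3ccc(Cl)cc3Cl)c2=O)=N1`: 14%
compound 2, `CC1=C(C(=O)Nc2ccc(F)cc2)C(c2ccc([N+](=O)[O-])cc2)n2c(s/c(=C/c3ccc(Cl)cc3Cl)c2=O)=N1`: 17%

In a functional assay on the whole organism (strain albino) for inhibition, with Rattus norvegicus as the target, read by paw edema, with stated times of 1 h and 3 h, at a dose of 25 mg/kg by the oral route (on this read-out higher numbers stand for more inhibition at the one dose given (going by the name of the read-out) and lower numbers for less inhibition), compound 1 gives 14%, and in this assay compound 2 gives 17%. Among the measured compounds shown here, compound 2 shows the larger of the two numbers, but the only measured step, a number 3 percentage points higher from compound 1 to compound 2 (within the scatter), lies within the scatter, so the two compounds are not separated by this assay.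

Compound 3, `COc1ccc(/C=c2/sc3n(c2=O)C(c2ccc([N+](=O)[O-])cc2)C(C(=O)Nc2ccc(F)cc2)=C(C)N=3)cc1`, differs from compound 2 in a single place: 4-methoxyphenyl in place of 2,4-dichlorophenyl on a double-bonded chain carbon bound to an aromatic carbon. The measured step between compound 1 and compound 2 concerns a different position, the swap of nitro for bromo on an aromatic carbon, and its size was small; it says nothing about the exchange of the aryl group on the double-bonded chain carbon. No measured comparison bears on this change, so for compound 3 no step beyond the scatter is expected in this assay, and the expected step is a number 1 percentage points higher from compound 2 to compound 3 (within the scatter). Compound 3 is therefore estimated to give 18%, within a range from 6% to 32%.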

Compound 3, a percentage reported as inhibition, in the whole organism at one dose (the size of the read-out at that dose, not a potency): 12%
Compound 3: middle estimate off by 6 percentage points, on the high side, and the stated range covers the measured number.
By their numbers in this assay, from the lowest: compounds 3, 1 and 2 (each within the scatter of the next).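

The exchange of 2,4-dichlorophenyl for 4-methoxyphenyl on a double-bonded chain carbon bound to an aromatic carbon now has a measured step: in this assay it amounts to a number 5 percentage points lower from compound 2 to compound 3 (within the scatter), so this assay does not separate the two aryl groups while the nitro group stays in place. The earlier pair spoke only to the swap of nitro for bromo, whereas this pair shows that the aryl group on the double bond can also be exchanged with a step that stays within the scatter, even though the entering group carries oxygen and a hydrogen-bond acceptor and the leaving group carries two chlorines. Nothing measured here gives a reason for the size of this step.

The compounds shown leave open whether any other group on this carbon would give a step beyond the scatter, for example a phenyl ring bearing an amine or a carboxylic acid, or a longer chain in place of the aromatic ring. They also leave open whether the same exchange would give a similar step with bromo in place of nitro, and how these compounds would compare at other doses.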